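This account rests on a few compounds, and the source may have more. Where it says the series, first, only, none or still open, it means among the compounds named here.

Measured compounds:
compound 1 `NCC[C@@H]1CCO[C@H](c2ccccc2)O1` — > 10000 nM
compound 2 `CC(C)(C)[C@@]1(c2ccccc2)OCC[C@@H](CCNCc2ccccc2)O1` — 128 nM
compound 3 `CC[C@@]1(c2ccccc2)OCC[C@@H](CCNCc2ccccc2)O1` — 20 nM

In an assay on brain for displacement of a labelled ligand from Sigma non-opioid intracellular receptor 1 (Cavia porcellus) (a higher number here means a weaker inhibitor, a lower number a stronger inhibitor), compound 3 gives 20 nM, the lowest of the two numbers in hand. Its nearest neighbour is compound 2 with 128 nM. For compound 1 the reported value > 10000 nM is a limit of the assay and not a number (the limit of > 10000 nM in this assay, at which 1 of the 3 values shown sits); compound 1 also lacks the benzyl on the amine that compound 2 and compound 3 carry, so its value says little about the ring substituent.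

Going by the values given here, the one measured step that bears on the next change is a 6.4-fold lower number from compound 2 to compound 3 (0.81 log units; beyond the scatter): a smaller alkyl at that ring carbon went with a lower number, beyond the scatter.

Compound 4 `c1ccc(CNCC[C@@H]2CCO[C@H](c3ccccc3)O2)cc1` differs from compound 3 by hydrogen in place of ethyl on a saturated ring carbon; it is the benzylated counterpart of compound 1. Whether the drop seen from tert-butyl to ethyl continues when the alkyl is removed altogether is not covered by any measured pair. The step is therefore expected to be small and is estimated as a 3.0-fold higher number from compound 3 to compound 4 (0.48 log units; beyond the scatter), with the direction uncertain. Compound 4 is expected to give about 60 nM in this assay, in the range 15 nM to 250 nM.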

Compound 4, inhibition constant: 6 nM
Estimate against measurement, compound 4: 10-fold (1.00 log units) above; measured number outside the range, below it.
By their numbers in this assay, from the lowest: compound 4; then compound 3; then compound 2. At a limit, above all of these: compound 1.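

In this assay the removal of the alkyl group continues the earlier direction, with a 3.3-fold lower number from compound 3 to compound 4 (0.52 log units; beyond the scatter) and, over the whole span, a 21-fold lower number from compound 2 to compound 4 (1.33 log units; beyond the scatter) at this saturated ring carbon between two ring oxygen atoms. The order tert-butyl, ethyl, hydrogen therefore runs one way across compound 2, compound 3 and compound 4, and none of the three goes against it, so hydrogen in place of ethyl gives no sign of a floor in this short series. Going by these compounds alone, compound 4 also gives the first pair that reads the benzyl on the amine nitrogen with the rest of the structure unchanged, and an at least 1600-fold lower number from compound 1 to compound 4 (3.22 log units; beyond the scatter) is a large step whose size rests on the fact that the value of compound 1 is a limit and not a number: the limit of > 10000 nM in this assay, at which 1 of the 4 values shown sits.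

The compounds shown leave open whether methyl at this ring carbon falls into the same order, and whether a phenylethyl group or a longer alkyl chain on the amine nitrogen keeps the number as low as that of compound 4. What lies behind the order also remains open, since it rests on three compounds alone.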